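Halogen swap on the phenyl ring: outlook for compound 4

The source may hold more compounds than are shown below. What is called first, only, known or untested is meant among the compounds shown, and "the series" means these compounds.

Measured in an assay on isolated protein for inhibition of Ephrin type-A receptor 2 (Homo sapiens), read by thermal shift assay, tested at 10 uM (a higher number here means that the compound stabilises the target more against heat, a lower number that the compound stabilises the target less), so far:
compound 1 `CC(C)(C)c1cc(NC(=O)Nc2cc(C(F)(F)F)cc(C(F)(F)F)c2)n(-c2ccccc2)n1` gives 0.8 degrees C
compound 2 `Cc1ccc(-n2nc(C(C)(C)C)cc2NC(=O)Nc2cc(C(F)(F)F)cc(C(F)(F)F)c2)cc1` gives 0.8 degrees C
compound 3 `CC(C)(C)c1cc(NC(=O)Nc2cc(C(F)(F)F)cc(C(F)(F)F)c2)n(-c2ccc(F)cc2)n1` gives 0.4 degrees C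

All three values lie within the scatter of one another; compound 3 sits within the scatter of both compound 1 and compound 2. Compound 4 `CC(C)(C)c1cc(NC(=O)Nc2cc(C(F)(F)F)cc(C(F)(F)F)c2)n(-c2ccc(Br)cc2)n1` differs from compound 3 by bromo in place of fluoro on an aromatic carbon. Going by the values given here, the steps that bear on this position are a number 0.40 degrees C lower from compound 1 to compound 3 (within the scatter) and a number 0.40 degrees C lower from compound 2 to compound 3 (within the scatter), both within the scatter, so hydrogen, methyl and fluoro at this carbon have left this assay unmoved. Among the compounds with values here, no bromo analogue is known. The expectation is therefore no step beyond the scatter, a number 0.10 degrees C higher from compound 3 to compound 4 (within the scatter). Compound 4 is estimated at 0.5 degrees C, with a range from -0.5 degrees C to 1.5 degrees C.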

Compound 4, shift of the target's melting temperature: 0.3 degrees C
Estimate against measurement, compound 4: 0.20 degrees C above; the range from low to high includes it.
By their numbers in this assay, from the lowest: compounds 4, 3, 1 and 2 (each within the scatter of the next).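

Bromo joins hydrogen, methyl and fluoro at this carbon with no step beyond the scatter: the steps are a number 0.10 degrees C lower from compound 3 to compound 4 (within the scatter), a number 0.50 degrees C lower from compound 2 to compound 4 (within the scatter) and a number 0.50 degrees C lower from compound 1 to compound 4 (within the scatter). The flat picture at this position therefore extends to a second halogen, through the change from 4-fluorophenyl to 4-bromophenyl. Nothing available explains this flatness. Going by these compounds, whether an amine or a carboxylic acid at this carbon would shift the melting temperature beyond the scatter stays open. So does whether any change elsewhere on the shared core would.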